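Swapping Iodo for Phenyl on a Shared Amide Core

The source may report more compounds than this note shows. Statements on the series, on what has been measured and on what is new or still open speak of the compounds shown alone.

Measured compounds:
Compound 1 `COc1cccc(OC)c1C(=O)Nc1nnc(-c2ccc(C(C)C)cc2)s1`: 398 nM
Compound 2 `COc1cccc(OC)c1C(=O)Nc1nnc(-c2ccc(I)cc2)s1`: 89.1 nM

Both compounds were tested in a functional assay on the whole organism (integument) for inhibition, with Chilo suppressalis as the target, read by scintillation counting, with a stated time of 72 h; on this read-out lower numbers stand for stronger inhibition and higher numbers for weaker inhibition. Going by the values given here, compound 2 gives the lower of the two numbers; the single step measured is a 4.5-fold lower number from compound 1 to compound 2 (0.65 log units; beyond the scatter), so compound 2 stands apart from compound 1 by more than the usual scatter. Compound 3 `COc1cccc(OC)c1C(=O)Nc1nnc(-c2ccc(-c3ccccc3)cc2)s1` has not yet been measured. It differs from compound 2 in one place: phenyl in place of iodo on an aromatic carbon. Among the compounds with values here, no measured step in this assay involves a phenyl entering or an iodo leaving; the one step available, a 4.5-fold lower number from compound 1 to compound 2 (0.65 log units; beyond the scatter), compares isopropyl with iodo and bears on the new change only loosely. Because a 4.5-fold lower number from compound 1 to compound 2 (0.65 log units; beyond the scatter) shows the number falling when isopropyl gave way to iodo, a modest rise is expected when iodo gives way to phenyl, a 2.2-fold higher number from compound 2 to compound 3 (0.35 log units; beyond the scatter). Compound 3 is estimated to give 200 nM in this assay, in a range from 50 nM to 800 nM.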

Compound 3, half-maximal inhibitory concentration: 195 nM
Estimate against measurement, compound 3: 1.0-fold (0.01 log units) above, and the stated range covers the measured number.
By their numbers in this assay, from the lowest: compound 2; then compound 3; then compound 1.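

In this assay, this carbon accepts a far bigger group at only a modest cost: phenyl brings six heavy atoms and a ring where iodo brought one heavy atom and no ring, and the result is a 2.2-fold higher number from compound 2 to compound 3 (0.34 log units; beyond the scatter) on the scale of this read-out. Phenyl also compares well with isopropyl, with a 2.0-fold lower number from compound 1 to compound 3 (0.31 log units; beyond the scatter) as the step, so the number does not simply rise as the group grows, and the three groups now fall in the order iodo, phenyl, isopropyl. No measured evidence is available to explain these differences.

The compounds shown leave open how an amine, a carboxylic acid or a longer chain on this same carbon would compare. They also leave open whether this order of groups would hold if the shared core were changed elsewhere.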